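A chain amide replaces the aryl ester on the ring nitrogen

The compounds below may be only part of what the source reports. "The series", "measured", "known", "first", "only" and "open" are said of these compounds alone.

Compound 1 `COC(=O)C(c1ccccc1)n1nnnc1[C@@H](COCc1ccccc1)NC(=O)C(C)(C)N`: 470 nM
Compound 2 `CC(C)(N)C(=O)N[C@H](COCc1ccccc1)c1nnn(CCCCC#N)n1`: > 5000 nM

Among the compounds with values here, in an assay on isolated protein for displacement of a labelled ligand from growth hormone secretagogue receptor type 1 (Homo sapiens), with a stated time of 1 h (a higher number here means a weaker inhibitor, a lower number a stronger inhibitor), compound 1 gives 470 nM, the only measured number in the set. Compound 2 gives only a limit, > 5000 nM, with the limit of > 5000 nM in this assay, at which 1 of the 2 values shown sits. Compound 3 `CCCCNC(=O)CCn1nnnc1[C@@H](COCc1ccccc1)NC(=O)C(C)(C)N` is not yet measured; it carries (2-(butylcarbamoyl)ethyl in place of methoxycarbonyl)(benzyl on an aromatic nitrogen), that is, 2-(butylcarbamoyl)ethyl in place of methoxycarbonyl)(benzyl on an aromatic nitrogen. Within the data shown here, no measured pair shows a change of this kind, so the step is expected to weaken binding by a 3.2-fold higher number from compound 1 to compound 3 (0.50 log units; beyond the scatter), beyond the usual scatter. Compound 3 is therefore estimated at 1500 nM, in the range 500 nM to 5000 nM.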

Compound 3, inhibition constant: 2190 nM
The estimate for compound 3 lay 1.5-fold (0.16 log units) below the measured number, and the stated range covers the measured number.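

On the aromatic nitrogen, replacing the group of compound 1, which carries a six-membered aromatic ring, with the ringless 2-(butylcarbamoyl)ethyl chain gives, in this assay, a 4.7-fold higher number from compound 1 to compound 3 (0.67 log units; beyond the scatter). The aromatic ring of this group is therefore not needed for a measurable value, as compound 3 still gives 2190 nM, although binding is weaker. Nothing shown gives a cause for this step. As far as these compounds go, the ester and the aromatic ring leave together, so their separate contributions remain open. From the compounds shown here alone, how a carboxylic acid or a longer chain on this nitrogen would behave also remains open.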